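The source may report more compounds than this note shows. Statements on the series, on what has been measured and on what is new or still open speak of the compounds shown alone.

Measured so far in a functional assay on HeLa cells (Homo sapiens) for antiproliferative activity, with a stated time of 24 h; a higher number here means a weaker inhibitor, a lower number a stronger inhibitor:
- compound 1, `NC(=O)c1c(NC(=O)c2ccccc2Cl)sc2c1CCN(Cc1ccccc1)C2`: 38400 nM
- compound 2, `NC(=O)c1c(NC(=O)c2ccccc2Cl)sc2c1CCN(C(=S)Nc1ccccc1C(F)(F)F)C2`: 26700 nM
- compound 3, `NC(=O)c1c(NC(=O)c2ccccc2Cl)sc2c1CCN(C(=S)Nc1ccccc1-c1ccccc1)C2`: 24000 nM

All three share one core and differ only in the group carried on the ring nitrogen. Compound 3 returns the smallest figure of the three, but its distance to compound 2 and its distance to compound 1 both fall within the scatter, so the three cannot be ranked against one another. Within the data shown here, the single one-point step available, a 1.1-fold lower number from compound 2 to compound 3 (0.05 log units; within the scatter), exchanged one substituent on the aromatic ring of the thiourea group for another and left the number where it was.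

Compound 4, `NC(=O)c1c(NC(=O)c2ccccc2Cl)sc2c1CCN(C(=S)Nc1c(Cl)cccc1Cl)C2`, differs from compound 3 by 2,6-dichlorophenyl in place of 2-phenylphenyl on an amide-type nitrogen. Among the measured compounds shown here, the step from compound 2 to compound 3 is the only measured step that bears on this change, as both alter the aryl group on the thiourea nitrogen, and it stayed within the scatter. For the measured compounds named here, no measured compound carries the 2,6-dichlorophenyl group itself. The step expected for this assay is therefore a 1.1-fold higher number from compound 3 to compound 4 (0.03 log units; within the scatter), nothing beyond the scatter. For compound 4 in this assay the estimate is 26000 nM, with a range from 11000 nM to 60000 nM.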

Compound 4, half-maximal inhibitory concentration: 26500 nM
The estimate for compound 4 lay 1.0-fold (0.01 log units) below the measured number; low and high end bracket the measured number.
By their numbers in this assay, from the lowest: compounds 3, 4, 2 and 1 (each within the scatter of the next).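

In this assay, 2,6-dichlorophenyl on the amide-type nitrogen of the thiourea gives no separation from 2-phenylphenyl (a 1.1-fold higher number from compound 3 to compound 4 (0.04 log units; within the scatter)) or from 2-(trifluoromethyl)phenyl (a 1.0-fold lower number from compound 2 to compound 4 (0.00 log units; within the scatter)), and both steps lie within the scatter. This aryl position now spans one ring or two and chlorine, trifluoromethyl or phenyl substituents without a readable change in the number. The step from the group on the ring nitrogen of compound 1 to the thiourea group of compound 4 (a 1.4-fold lower number from compound 1 to compound 4 (0.16 log units; within the scatter)) also stays within the scatter, and nothing measured here accounts for this flat result.

Still open, from the compounds shown here alone, is whether an aryl ring carrying an amine or a carboxylic acid would move the number beyond the scatter. Going by these compounds, a longer alkyl chain in place of the aryl group on this nitrogen is equally open.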